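The compounds below may be only part of what the source reports. "The series", "measured", "known", "first", "only" and "open" are said of these compounds alone.

In a functional assay on HCT-116 cells (Homo sapiens) for antiproliferative activity, read by MTT assay, with a stated time of 72 h (on this read-out lower numbers stand for stronger inhibition and higher numbers for weaker inhibition), compound 2 `CC(C)C[C@H](NC(=O)CNC(=O)N1C/C(=C\c2ccc(F)cc2)C(=O)/C(=C/c2ccc(F)cc2)C1)B1OC(C)(C)C(C)(C)O1` gives 375 nM and so sits close to compound 1 `CC(C)C[C@H](NC(=O)[C@H](CC(C)C)NC(=O)N1C/C(=C\c2ccc(F)cc2)C(=O)/C(=C/c2ccc(F)cc2)C1)B1OC(C)(C)C(C)(C)O1`, which gives 639 nM in the same test; those two values lie within the usual scatter of each other. Compound 3 `CC(C)[C@H](NC(=O)N1C/C(=C\c2ccc(F)cc2)C(=O)/C(=C/c2ccc(F)cc2)C1)B1OC(C)(C)C(C)(C)O1` gives 908 nM as its result, a higher number than compound 2 shows, and that gap lies beyond the scatter.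

Compound 4 `CC(C)C[C@H](NC(=O)[C@@H](NC(=O)N1C/C(=C\c2ccc(F)cc2)C(=O)/C(=C/c2ccc(F)cc2)C1)C(C)C)B1OC(C)(C)C(C)(C)O1` differs from compound 2 in one place, described by isopropyl in place of hydrogen on a saturated chain carbon bound to an amide-type nitrogen and a carbonyl carbon and amounting to isopropyl in place of hydrogen on a saturated chain carbon bound to an amide-type nitrogen and a carbonyl carbon. Among the compounds with values here, one measured step bears on this: at the same kind of carbon, hydrogen in place of isobutyl gives a 1.7-fold lower number from compound 1 to compound 2 (0.23 log units; within the scatter) and stays within the scatter. Within the data shown here, no measured compound carries isopropyl there, so a 1.7-fold lower number from compound 1 to compound 2 (0.23 log units; within the scatter) read in reverse is only a rough guide. It points to a small expected rise in the number in this assay for compound 4, not one beyond the scatter. The expected size of the change is a 1.5-fold higher number from compound 2 to compound 4 (0.19 log units; within the scatter) by this estimate. For compound 4 the estimate is 580 nM with an expected range from 280 nM to 1200 nM in this test.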

Compound 4, half-maximal inhibitory concentration: 534 nM
Compound 4: the middle estimate sits 1.1-fold (0.04 log units) above what was measured; low and high end bracket the measured number.
By their numbers in this assay, from the lowest: compounds 2, 4, 1 and 3 (each within the scatter of the next, the first and the last beyond it).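

In this assay, isopropyl in place of hydrogen on a saturated chain carbon bound to an amide-type nitrogen and a carbonyl carbon gives a small change (a 1.4-fold higher number from compound 2 to compound 4 (0.15 log units; within the scatter)), so a second group at this carbon, after the isobutyl of compound 1, stays close to hydrogen. The new compound also allows a direct comparison of the two larger groups, with isopropyl in place of isobutyl (a 1.2-fold lower number from compound 1 to compound 4 (0.08 log units; within the scatter)), which means that hydrogen, isopropyl and isobutyl at this carbon all lie within the scatter of one another in this test. Nothing available here explains why these three groups give such similar numbers.

As far as these compounds go, all three groups at this carbon are hydrogen or plain carbon chains, so it remains open whether an amine, a carboxylic acid or a phenyl ring there would keep the number in the same range or move it beyond the scatter. From the compounds shown here alone, it also remains open whether the same closeness among compounds 1, 2 and 4 would appear in cell lines other than this one.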